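Moving the hydroxyl in a trifluoromethylphenyl analogue

The source may hold more compounds than are shown below. What is called first, only, known or untested is meant among the compounds shown, and "the series" means these compounds.

Compound 2 `Oc1ccc(-c2cc(-c3cccc(C(F)(F)F)c3)cc(-c3ccccc3O)n2)cc1` gives > 50000 nM in a functional assay on T47D cells (Homo sapiens) for inhibition (a higher number here means a weaker inhibitor, a lower number a stronger inhibitor), which is a limit of the assay and not a number. Compound 2 thus stands at the limit of > 50000 nM in this assay, at which 1 of the 2 values shown sits, and cannot be placed on the scale. Compound 1 `Oc1ccc(-c2cc(-c3ccccc3F)cc(-c3ccc(O)cc3)n2)cc1` is measured within the scale: in this assay compound 1 gives 15100 nM. Compound 3 `Oc1ccc(-c2cc(-c3cccc(C(F)(F)F)c3)cc(-c3ccc(O)cc3)n2)cc1` differs from compound 2 by 4-hydroxyphenyl in place of 2-hydroxyphenyl on an aromatic carbon, in words 4-hydroxyphenyl in place of 2-hydroxyphenyl on an aromatic carbon. Among the measured compounds shown here, no measured step covers this change, so its size is open. Compound 3 carries two 4-hydroxyphenyl groups on the shared core, as compound 1 does, and compound 1 is measured on the scale at 15100 nM. Compound 3 is therefore expected to fall within the scale as well, in the direction of stronger inhibition, though a reported limit remains possible. The expected step is an at least 2.5-fold lower number from compound 2 to compound 3 (0.39 log units; beyond the scatter). Compound 3 is estimated at 20000 nM, with a range from 8000 nM to 50000 nM.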

Compound 3, half-maximal inhibitory concentration: > 50000 nM
Compound 3 was reported as a limit; the forecaster's own chance of this, stated with the estimate: 35%; at least 2.5-fold (0.39 log units) between middle value and limit.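

In this assay compound 3 gives > 50000 nM, which is a limit of the assay and not a number. 4-Hydroxyphenyl in place of 2-hydroxyphenyl thus does not bring this trifluoromethylphenyl analogue onto the scale, and the size of the step between compound 2 and compound 3 cannot be read: the limit of > 50000 nM in this assay, at which 2 of the 3 values shown sit. With two 4-hydroxyphenyl groups on the shared core, 3-(trifluoromethyl)phenyl in place of 2-fluorophenyl gives an at least 3.3-fold higher number from compound 1 to compound 3 (0.51 log units; beyond the scatter), so the change at that other position alone separates a measured value from a limit.

On these data alone, how 2-hydroxyphenyl behaves alongside 2-fluorophenyl on the shared core stays open. Also open, as far as these compounds go, is whether an amine or a carboxylic acid in place of the hydroxyl would bring a trifluoromethylphenyl analogue onto the scale.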